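The source may hold more compounds than are shown below. What is called first, only, known or untested is meant among the compounds shown, and "the series" means these compounds.

Of the compounds shown here, two have been read so far in an ADME assay on microsomes from liver (Mus musculus) for metabolic stability (on this read-out lower numbers stand for a shorter-lived compound and higher numbers for a longer-lived compound), and their numbers sit close together. Compound 1 `O=C(C[C@H]1CC[C@]2(CC1)OO[C@]1(O2)C2CC3CC(C2)CC1C3)N1CCNCC1` gives 0.802 h and compound 2 `NC(=O)CNC(=O)C[C@@H]1CCC[C@]2(C1)OOC1(O2)C2CC3CC(C2)CC1C3` gives 0.622 h there, which places compound 2 within the scatter of compound 1. Going by the values given here, these two structures differ in more than one place, so no measured step offers a direct guide. Compound 3 `CC(C)(CN)CNC(=O)C[C@@H]1CCC[C@]2(C1)OOC1(O2)C2CC3CC(C2)CC1C3` carries 1-(aminomethyl)-1-methylethyl in place of carbamoyl on a saturated chain carbon bound to an amide-type nitrogen and otherwise keeps the structure of compound 2. Cut one bond further out, the same difference reads (carbamoylmethyl)carbamoyl to (2-(aminomethyl)-2-methylpropyl)carbamoyl. No shift beyond the scatter is expected in this assay in either direction. That expectation leans on compound 2 at 0.622 h and compound 1 at 0.802 h lying level even though their structures differ by more than this single change. The estimated 1.0-fold higher number from compound 2 to compound 3 (0.02 log units; within the scatter) is therefore expected to stay small. Compound 3 is expected at about 0.65 h with an estimated range of 0.28 h to 1.5 h for repeat measurements.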

Compound 3, half-life: 1.07 h
Compound 3: the middle estimate sits 1.6-fold (0.22 log units) below what was measured; low and high end bracket the measured number.
By their numbers in this assay, from the lowest: compounds 2, 1 and 3 (each within the scatter of the next).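

Going by these compounds alone, this is the first comparison in this assay between compounds that differ in one place, and it gives a 1.7-fold higher number from compound 2 to compound 3 (0.24 log units; within the scatter), so on a saturated chain carbon bound to an amide-type nitrogen, 1-(aminomethyl)-1-methylethyl and carbamoyl cannot be told apart on this read-out. The exchange replaces 3 heavy atoms with 5 and removes the double bond outside aromatic rings, while the hydrogen-bond donor and acceptor counts stay the same and neither group has a ring or a net charge; even so, the step stays within the scatter. No measurement shown here accounts for this result, so the step can only be recorded as it stands.

On these data alone, what remains open is whether this place would stay as undemanding with a carboxylic acid, a hydroxymethyl group or a longer chain in place of carbamoyl. It is also unknown whether the same exchange would read the same way on the core of compound 1, since the compounds shown offer no matching pair there.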